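A few compounds are considered here, and "the series" means these few. Any claim that something is new, unique, unknown or untested is made for them only; others in the source may bear on it.

Measured in a functional assay on COLO 205 cells (Homo sapiens) for inhibition, read by sulforhodamine B assay, with a stated time of 48 h, tested at 50 uM; on this read-out lower numbers stand for less inhibition of growth and higher numbers for more inhibition of growth at the one concentration tested:
- compound 1 `COc1cc(/C=C/C(=O)/C=C/c2cccc3ccccc23)ccc1OCc1cn(CCCCCOc2cc(=O)oc3ccccc23)nn1`: 40%
- compound 2 `COc1cccc(/C=C/C(=O)/C=C/c2ccc(OCc3cn(CCCCCOc4cc(=O)oc5ccccc45)nn3)c(OC)c2)c1`: 34%
- compound 3 `COc1ccc(/C=C/C(=O)/C=C/c2ccc(OCc3cn(CCCCCOc4cc(=O)oc5ccccc45)nn3)c(OC)c2)cc1`: 30%

In this assay compound 3 gives 30%, and neither compound 1 nor compound 2 is separated from it beyond the scatter. Compound 4 `COc1cc(/C=C/C(=O)/C=C/c2ccccc2)ccc1OCc1cn(CCCCCOc2cc(=O)oc3ccccc23)nn1` departs from compound 3 by hydrogen in place of methoxy on an aromatic carbon, so that 4-methoxyphenyl becomes phenyl.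

Going by the values given here, no measured pair shows this exact change. The nearest evidence comes from steps at the same end of the molecule. These are a number 4 percentage points lower from compound 2 to compound 3 (within the scatter), a number 10 percentage points lower from compound 1 to compound 3 (within the scatter) and a number 6 percentage points lower from compound 1 to compound 2 (within the scatter). Since all of these stay inside the scatter, replacing this aryl group has not yet moved the read-out measurably in this small set. No step beyond the scatter is therefore expected in this assay. The expected change is a number 3 percentage points higher from compound 3 to compound 4 (within the scatter). For compound 4 the estimated value is 33%, with an expected range from 22% to 44%.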

Compound 4, percent growth inhibition at one concentration: 22%
Estimate against measurement, compound 4: 11 percentage points above, and the stated range covers the measured number.
By their numbers in this assay, from the lowest: compounds 4, 3, 2 and 1 (each within the scatter of the next, the first and the last beyond it).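

In this assay, hydrogen in place of methoxy on the 4-methoxyphenyl group does not by itself separate the two compounds (a number 8 percentage points lower from compound 3 to compound 4 (within the scatter)). The phenyl group nevertheless gives the first differences in this set that pass the scatter, though both are modest: against 3-methoxyphenyl (a number 12 percentage points lower from compound 2 to compound 4 (beyond the scatter)) and against naphthalen-1-yl (a number 18 percentage points lower from compound 1 to compound 4 (beyond the scatter)). This end of the molecule can therefore register on this read-out, although no measurement shown offers a reason for it.

The compounds shown leave open whether an aromatic ring carrying an amine or a carboxylic acid at this place would give a number outside the range seen so far. They also leave open whether a longer chain within the shared core would change these differences.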